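Chloro Substitution on the Sulfonyl Ring in Two Series

A few compounds are considered here, and "the series" means these few. Any claim that something is new, unique, unknown or untested is made for them only; others in the source may bear on it.

Compound 1 `O=C(Nc1cnn(-c2ccccc2)c1)c1cccc(NS(=O)(=O)c2ccccc2)c1` and compound 2 `O=C(Nc1cnn(-c2ccccc2)c1)c1cccc(NS(=O)(=O)c2ccc(Cl)cc2)c1` differ in one change: chloro in place of hydrogen on an aromatic carbon. In a functional assay on HeLa cells (Homo sapiens) for inhibition, read by MTT assay, with a stated time of 48 h (a higher number here means a weaker inhibitor, a lower number a stronger inhibitor), compound 1 gives 15300 nM, while compound 2 gives 5410 nM; the measured step is a 2.8-fold lower number from compound 1 to compound 2 (0.45 log units; beyond the scatter). Compound 3 `Cc1ccc(-n2cc(NC(=O)c3ccc(NS(=O)(=O)c4ccccc4)cc3)cn2)cc1` rests on another core, and the difference between the two cores is not broken down here. In this assay compound 3 gives 27900 nM. Compound 4 `Cc1ccc(-n2cc(NC(=O)c3ccc(NS(=O)(=O)c4ccc(Cl)cc4)cc3)cn2)cc1` is not yet measured; it differs from compound 3 by the same change, at the same kind of place: chloro in place of hydrogen on an aromatic carbon. Going by the values given here, because a 2.8-fold lower number from compound 1 to compound 2 (0.45 log units; beyond the scatter) is the only measured example of this change, a step of similar size is expected here: a 2.8-fold lower number from compound 3 to compound 4 (0.45 log units; beyond the scatter). Compound 4 is therefore estimated at 10000 nM, with a likely range from 4000 nM to 25000 nM in this assay.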

Compound 4, half-maximal inhibitory concentration: 8010 nM
Beside the measured number, compound 4's estimate is 1.2-fold (0.10 log units) above it; the measured number falls inside the stated range.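

In this assay, chloro in place of hydrogen gives a 3.5-fold lower number from compound 3 to compound 4 (0.54 log units; beyond the scatter), and this step agrees with the one seen earlier on the other core: the same change on two cores in this assay, a 2.8-fold lower number (0.45 log units; beyond the scatter) from compound 1 to compound 2 and a 3.5-fold lower number (0.54 log units; beyond the scatter) from compound 3 to compound 4, 1.2-fold (0.09 log units) apart, within the scatter of two such steps. On these two cores, then, the change lowers the number by a similar amount, so a step measured on one core was a fair guide to the other. This does not show that the step would carry over to a further core, and two pairs alone cannot explain why chloro lowers the number.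

The compounds shown leave open whether fluoro, methoxy or an amine at the same place would move the number in the same way. They also leave open what chloro would do elsewhere on that ring.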